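Adding Methoxy to a Phenyl Ring: What to Expect

The source may report more compounds than this note shows. Statements on the series, on what has been measured and on what is new or still open speak of the compounds shown alone.

In an ADME assay on MT4 cells (Homo sapiens) for cytotoxicity, read by spectrophotometry, with a stated time of 5 days (a higher number here means that more compound is tolerated, a lower number that less compound is tolerated), compound 2 (`Cc1ccc2c(c1)/C(=N/NC(=S)NO)C(=O)N2CN1CCN(c2ccccc2)CC1`) gives 420000 nM and stands level with compound 1 (`Cc1ccc2c(c1)/C(=N/NC(=S)NO)C(=O)N2CN1CCN(c2ccc(Cl)cc2)CC1`) at 335000 nM within the usual scatter. Within the data shown here, these two compounds differ in one place, and putting hydrogen in place of chloro on an aromatic carbon gave a 1.3-fold higher number from compound 1 to compound 2 (0.10 log units; within the scatter) as the only measured step. Compound 3 (`COc1ccc(N2CCN(CN3C(=O)/C(=N\NC(=S)NO)c4cc(C)ccc43)CC2)cc1`) has not yet been measured. It carries methoxy in place of hydrogen on an aromatic carbon and so turns phenyl into 4-methoxyphenyl. Among the measured compounds shown here, one small step is thin evidence, and methoxy itself has never been tested here, but nothing measured so far points to a large change. The expected change is a 1.1-fold lower number from compound 2 to compound 3 (0.04 log units; within the scatter) and thus no step beyond the scatter in either direction. For compound 3 the estimate is 380000 nM with an expected range from 200000 nM to 650000 nM in this assay once it is measured.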

Compound 3, half-maximal cytotoxic concentration: 321000 nM
Estimate against measurement, compound 3: 1.2-fold (0.07 log units) above; the range from low to high includes it.
By their numbers in this assay, from the lowest: compounds 3, 1 and 2 (each within the scatter of the next).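

Three different groups have now been compared at this ring position, para to a large group: hydrogen, chloro and 4-methoxyphenyl's methoxy. Replacing hydrogen with methoxy (a 1.3-fold lower number from compound 2 to compound 3 (0.12 log units; within the scatter)) and replacing chloro with methoxy (a 1.0-fold lower number from compound 1 to compound 3 (0.02 log units; within the scatter)) both stay within the scatter, so compounds 1, 2 and 3 cannot be told apart in this assay and neither swap shows a real effect on how much compound the cells tolerate. No supporting measurement bears on why these numbers lie so close together.

The compounds shown leave open how an amine, a carboxylic acid or a longer chain such as butoxy would read at this position. They also leave open whether any group placed here can move the number beyond the scatter.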